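Trimming the amide-bearing side chain down to glycine

The source may hold more compounds than are shown below. What is called first, only, known or untested is meant among the compounds shown, and "the series" means these compounds.

Compound 3 `CCCCCCCCCCCCCC(=O)NCc1ccc(C(=O)N[C@@H](CCC(N)=O)C(=O)O)cc1` holds the highest of the two plain numbers in a toxicity assay on cells (Erythrocyte, Homo sapiens) for cytotoxicity, read by hemolysis (a higher number here means that more compound is needed for the effect, a lower number that less compound is needed), where compound 3 gives 520 ug/mL. Its nearest neighbour is compound 1 `CCCCCCCCCCCCCC(=O)NCc1ccc(C(=O)N[C@H](C(=O)O)[C@@H](C)CC)cc1`, which in this assay gives 66 ug/mL; the step of a 7.9-fold higher number from compound 1 to compound 3 (0.90 log units; beyond the scatter). Compound 2 `CCCCCCCCCCCCCC(=O)NCc1ccc(C(=O)N[C@@H](CC(N)=O)C(=O)O)cc1` in this assay gives only a limit, > 10 ug/mL. Compound 4 `CCCCCCCCCCCCCC(=O)NCc1ccc(C(=O)NCC(=O)O)cc1` carries the change (hydrogen in place of 2-carbamoylethyl on a saturated chain carbon bound to an amide-type nitrogen and a carbonyl carbon). Among the compounds with values here, no measured pair strips this position bare; the step of a 7.9-fold higher number from compound 1 to compound 3 (0.90 log units; beyond the scatter) shows only that the group here moves the read-out, and a step that the limit leaves unreadable from compound 1 to compound 2 is unreadable. Removing the 2-carbamoylethyl group is therefore expected to shift compound 4 only moderately from compound 3, a 1.7-fold lower number from compound 3 to compound 4 (0.24 log units; within the scatter). Compound 4 is estimated at 300 ug/mL, between 100 ug/mL and 900 ug/mL.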

Compound 4, half-maximal effective concentration: > 50 ug/mL
Compound 4: a limit, no number (the forecaster's own chance of this, stated with the estimate: 20%); the middle value lies beyond the limit too.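

In this assay compound 4 gives only a limit of > 50 ug/mL and no number, and none of its steps from compound 1, compound 2 or compound 3 can be read. Where compound 4 actually stands relative to these compounds remains open.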